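Swapping the Thiosemicarbazone Tail on Two Related Cores

The compounds below may be only part of what the source reports. "The series", "measured", "known", "first", "only" and "open" are said of these compounds alone.

Compound 1 `Cc1cccc(NC2=C/C(=N/NC(N)=S)C(=O)N=C2Nc2cccc(C)c2)c1` and compound 3 `Cc1cccc(NC2=C/C(=N/N=C(\N)SCc3ccccc3)C(=O)N=C2Nc2cccc(C)c2)c1` share one core and differ in a single place: a group of 11 heavy atoms (8 carbon, 2 nitrogen, 1 sulfur; one six-membered aromatic ring of carbon only) in place of a group of 4 heavy atoms (1 carbon, 2 nitrogen, 1 sulfur; no ring), on a double-bonded nitrogen. In a functional assay on HCT-116 cells (Homo sapiens) for antiproliferative activity, read by MTT assay, with a stated time of 72 h (a higher number here means a weaker inhibitor, a lower number a stronger inhibitor), compound 1 gives 8650 nM, and compound 3 gives 12900 nM; the step is a 1.5-fold higher number from compound 1 to compound 3 (0.17 log units; within the scatter), so the two numbers cannot be told apart. Compound 2 `NC(=S)N/N=C1/C=C(Nc2ccc(F)cc2)C(Nc2ccc(F)cc2)=NC1=O` is built on a different core, and the difference between the two cores is not broken down here. In this assay compound 2 gives 3720 nM, the lowest of the three numbers, and its gaps to compound 1 and compound 3 both lie beyond the scatter. Compound 4 `N/C(=N\N=C1\C=C(Nc2ccc(F)cc2)C(Nc2ccc(F)cc2)=NC1=O)SCc1ccccc1` has not yet been measured. It stands to compound 2 as compound 3 stands to compound 1: a group of 11 heavy atoms (8 carbon, 2 nitrogen, 1 sulfur; one six-membered aromatic ring of carbon only) in place of a group of 4 heavy atoms (1 carbon, 2 nitrogen, 1 sulfur; no ring), on a double-bonded nitrogen. The surroundings of the place are described in the same words for both pairs, so this is the same change. A similar small step is expected, a 1.5-fold higher number from compound 2 to compound 4 (0.18 log units; within the scatter), because the earlier step was a 1.5-fold higher number from compound 1 to compound 3 (0.17 log units; within the scatter) and lay within the scatter. Compound 4 is therefore estimated at 5600 nM, expected to fall between 2500 nM and 13000 nM.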

Compound 4, half-maximal inhibitory concentration: 11500 nM
Compound 4: the middle estimate sits 2.1-fold (0.31 log units) below what was measured; the range from low to high includes it.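

In this assay, the larger group with its six-membered aromatic ring of carbon only, placed on the core of compound 2, gives a 3.1-fold higher number from compound 2 to compound 4 (0.49 log units; beyond the scatter), a step that can be told apart from the scatter. Set beside the step on the core of compound 1, the two results do not differ by more than repeated measurements could explain: the same change on two cores in this assay, a 1.5-fold higher number (0.17 log units; within the scatter) from compound 1 to compound 3 and a 3.1-fold higher number (0.49 log units; beyond the scatter) from compound 2 to compound 4, 2.1-fold (0.32 log units) apart, within the scatter of two such steps This shows that nothing here separates the effect of the change on one core from its effect on the other, but it does not show that the effect is the same, as only two pairs are available and only the step on the core of compound 2 lies beyond the scatter.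

The compounds shown leave open how a smaller methyl group, a longer alkyl chain or an amine would behave at this place, on a double-bonded nitrogen. They also leave open whether the change would act alike on a core bearing other groups, such as a methoxy or a chlorine, on its two outer aromatic rings.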